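The compounds below may be only part of what the source reports. "The series", "measured", "known", "first", "only" and "open" are said of these compounds alone.

Working notes on the series, read in a functional assay on MGC-803 cells (Homo sapiens) for inhibition, read by MTT assay, with a stated time of 48 h; a higher number here means a weaker inhibitor, a lower number a stronger inhibitor. Among the compounds with values here, compound 1 (`CC/C=C/C(=O)N(Cc1ccc(OC)c(O)c1)c1cc(OC)c(OC)c(OC)c1`) gives 58 nM, and compound 2 (`COc1ccc(CN(C(=O)C[Se]C#N)c2cc(OC)c(OC)c(OC)c2)cc1O`) gives 270 nM, so compound 2 holds the higher, weaker number of the two measured so far. Compound 3 (`COc1ccc(CN(C(=O)CBr)c2cc(OC)c(OC)c(OC)c2)cc1O`) keeps the core of compound 2 and changes only the group on a saturated chain carbon bound to a carbonyl carbon: one bromine atom in place of a group of 3 heavy atoms (1 carbon, 1 nitrogen, 1 selenium; no ring), on a saturated chain carbon bound to a carbonyl carbon. Within the data shown here, one measured step bears on this change, and only loosely: a 4.7-fold higher number from compound 1 to compound 2 (0.67 log units; beyond the scatter). This modest step lies beyond the scatter, but it replaces the whole group on the carbonyl carbon, so it does not isolate the part that now leaves. Among the measured compounds shown here, no measured pair tests a bromo group, and the direction of the change therefore remains open. No step beyond the scatter is expected in this assay, and the estimated change is a 1.1-fold lower number from compound 2 to compound 3 (0.03 log units; within the scatter). Compound 3 is estimated at 250 nM, with an expected range of 70 nM to 900 nM.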

Compound 3, half-maximal inhibitory concentration: 140 nM
For compound 3 the middle estimate is 1.8-fold (0.25 log units) above the measured one; low and high end bracket the measured number.
By their numbers in this assay, from the lowest: compound 1; then compounds 3 and 2 (each within the scatter of the next).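

In this assay the exchange on a saturated chain carbon bound to a carbonyl carbon gives a 1.9-fold lower number from compound 2 to compound 3 (0.29 log units; within the scatter) and so does not separate bromo from the group of carbon, nitrogen and selenium it replaces; selenium is therefore not needed for a number at this level in these two compounds. The comparison with the but-1-en-1-yl group gives a 2.4-fold higher number from compound 1 to compound 3 (0.38 log units; beyond the scatter) and shows that bromomethyl, like the group on the carbonyl carbon of compound 2, stays beyond the scatter from compound 1, which remains the strongest inhibitor of the three. No measurement at hand explains these numbers or says what either group does in the cells.

Going by these compounds, whether a chlorine or iodine atom, an amine or a longer chain on the same saturated chain carbon would stay at the level of compounds 2 and 3 remains open. Also open, on these data alone, is whether an acetyl group, with a plain hydrogen in place of bromo, would keep this level, which would show whether the carbon needs any such substituent at all.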